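The source may hold more compounds than are shown below. What is called first, only, known or untested is meant among the compounds shown, and "the series" means these compounds.

Measured in a functional assay on L929 cells (Mus musculus) for antiproliferative activity, read by MTT assay; on this read-out lower numbers stand for stronger inhibition and higher numbers for weaker inhibition:
compound 1 `CC1(C)COC2(C[C@@H]3CC=C[C@@H]3C2)OC1`: > 40 ug/mL
compound 2 `CC(C)(C)[Si](O[C@H]1C[C@H]2CC(=O)C[C@H]2C1)(c1ccccc1)c1ccccc1`: > 40 ug/mL
compound 3 `CC(C)(C)[Si](OC1CCCCCC1)(c1ccccc1)c1ccccc1`: 40 ug/mL

Compound 1 gives > 40 ug/mL, which is a limit of the assay and not a number. Compound 2 gives > 40 ug/mL, which is likewise a limit. For the measured compounds named here, compound 3, at 40 ug/mL, holds the only actual number in the set, so it cannot be ranked against the other two compounds.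

The next compound is compound 4 `CC(C)(C)[Si](OC1CCCCC1)(c1ccccc1)c1ccccc1`, and the change is cyclohexyl in place of cycloheptyl on an oxygen. Neither group carries a hydrogen-bond donor or acceptor, or a net charge.

Going by the values given here, one measured step bears on this change, since it also alters the group on an oxygen: a number no higher from compound 2 to compound 3 (the limit leaves the size open). Its size cannot be read. Among the compounds with values here, the set otherwise offers (the limit of > 40 ug/mL in this assay, at which 2 of the 3 values shown sit), so no measured step supplies a size for the change at hand.

The expectation therefore rests on compound 3 at 40 ug/mL, with no shift beyond the scatter expected in this assay. The expected step is no change at the digits printed from compound 3 to compound 4 (within the scatter). For compound 4 the estimate is 40 ug/mL, with an expected range of 20 ug/mL to 80 ug/mL. A report of only a limit is expected about as often as a number.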

Compound 4, half-maximal inhibitory concentration: 40 ug/mL
Compound 4: the middle estimate sits on the measured number at the digits printed, within the range that was stated.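

In this assay, cyclohexyl in place of cycloheptyl on an oxygen gives no change at the digits printed from compound 3 to compound 4 (within the scatter). For the compounds shown here, this is the first step in the set that can be read at this place, since the other steps here start from a limit and cannot be read, among them a number no higher from compound 2 to compound 4 (the limit leaves the size open); it shows that, for these two carbon-only rings, going from the seven-membered to the six-membered ring leaves the read-out unmoved at the digits printed. Compound 4 also gives the set a second actual number, but other compounds in the set still have none: the limit of > 40 ug/mL in this assay, at which 2 of the 4 values shown sit.

The compounds shown leave open whether any group on this oxygen would give a clearly lower number than compound 4, for example a longer chain such as octyl, an aminoethyl group or a group carrying a carboxylic acid. They also leave open what happens on changing the groups on silicon, such as phenyl to methyl, with the cycloheptyl or cyclohexyl ring kept in place.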